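A Longer Ester Arm on a Scaffold Without Toxicity

This account rests on a few compounds, and the source may have more. Where it says the series, first, only, none or still open, it means among the compounds named here.

Compound 1 `Cc1cn([C@@H]2O[C@H](CO[Si](C)(C)C(C)(C)C)[C@@]3(OS(=O)(=O)C=C3NCC(N)=O)[C@H]2O[Si](C)(C)C(C)(C)C)c(=O)n(C)c1=O` is the only one of the three measured compounds to give a number in a functional assay on HEL cells (Homo sapiens) for cytotoxicity, read by microscopy (on this read-out higher numbers stand for lower toxicity in this test and lower numbers for higher toxicity in this test), where compound 1 shows 16000 nM. Compound 2 `COC(=O)CNC1=CS(=O)(=O)O[C@@]12[C@@H](CO[Si](C)(C)C(C)(C)C)O[C@@H](n1cc(C)c(=O)n(C)c1=O)[C@@H]2O[Si](C)(C)C(C)(C)C` reaches only a limit of the test, and in this assay compound 2 gives >= 400000 nM. Compound 3 `Cc1cn([C@@H]2O[C@H](CO[Si](C)(C)C(C)(C)C)[C@@]3(OS(=O)(=O)C=C3NCC(=O)OCc3ccccc3)[C@H]2O[Si](C)(C)C(C)(C)C)c(=O)n(C)c1=O` likewise reaches only a limit, and in this assay compound 3 gives >= 400000 nM. The two steps away from compound 1 are large, an at least 25-fold higher number from compound 1 to compound 2 (1.39 log units; beyond the scatter) and an at least 25-fold higher number from compound 1 to compound 3 (1.39 log units; beyond the scatter), whereas a step that the two limits leave unreadable from compound 2 to compound 3. Compound 3 thus stands at the limit of >= 400000 nM in this assay, at which 2 of the 3 values shown sit, with compound 2 beside it.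

Compound 4 `Cc1cn([C@@H]2O[C@H](CO[Si](C)(C)C(C)(C)C)[C@@]3(OS(=O)(=O)C=C3NCCC(=O)OCc3ccccc3)[C@H]2O[Si](C)(C)C(C)(C)C)c(=O)n(C)c1=O` differs from compound 3 by (benzyloxycarbonyl)methyl in place of benzyloxycarbonyl on a saturated chain carbon bound to an amine nitrogen. Going by the values given here, no measured step changes the length of this chain, so the step from compound 3 to compound 4 has no direct counterpart among the measured pairs; the two large steps from compound 1 concern the ester in place of the amide, not the chain. Compound 3 sits at a limit, and compound 4 is expected to remain at or near it, so the expected step is a number no higher from compound 3 to compound 4 (the limit leaves the size open). The estimate for compound 4 in this assay is 400000 nM, between 100000 nM and 800000 nM.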

Compound 4, minimum cytotoxic concentration: >= 400000 nM
Compound 4 ended at the assay's limit; the forecaster's own chance of this, stated with the estimate: 75%; the middle value lies on the limit itself.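

In this assay compound 4 gives >= 400000 nM, which is a limit of the test and not a number. Going by these compounds alone, the change from benzyloxycarbonyl to (benzyloxycarbonyl)methyl on a saturated chain carbon bound to an amine nitrogen is the first change of chain length in this set, and the longer ester arm joins the shorter ones, with only compound 1, the carbamoyl compound, standing apart: the limit of >= 400000 nM in this assay, at which 3 of the 4 values shown sit. Against that carbamoyl arm, the longer ester arm still shows an at least 25-fold higher number from compound 1 to compound 4 (1.39 log units; beyond the scatter), so the pattern of ester arms sitting far from the amide now holds for two chain lengths, while the steps among compound 2, compound 3 and compound 4 cannot be read.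

From the compounds shown here alone, how compound 2, compound 3 and compound 4 rank among themselves in this assay stays open, and so does any effect of chain length taken alone. Also open, going by these compounds, is whether a primary amide on the longer chain would return to a number near that of compound 1, and how a carboxylic acid or an amine at the end of the chain would read in this test.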